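Trimming the chain: a shorter amide in compound 3

A few compounds are considered here, and "the series" means these few. Any claim that something is new, unique, unknown or untested is made for them only; others in the source may bear on it.

Of the compounds shown here, two have been tested in an ADME assay on MT4 cells (Homo sapiens) for cytotoxicity, read by MTT assay; on this read-out higher numbers stand for lower toxicity in this test and lower numbers for higher toxicity in this test. Compound 1 `Cc1cc(C)cc(S(=O)(=O)c2c(C(=O)NCC(=O)NC(C)c3ccccc3)[nH]c3ccc(Cl)cc23)c1` gives 29400 nM. Compound 2 `Cc1cc(C)cc(S(=O)(=O)c2c(C(=O)NC(C)C(=O)NCc3ccncc3)[nH]c3ccc(Cl)cc23)c1` gives 19500 nM, the lowest of the two numbers, though its nearest neighbour is compound 1 and the difference a 1.5-fold lower number from compound 1 to compound 2 (0.18 log units; within the scatter) lies within the scatter, so the two cannot be told apart.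

Compound 3 `Cc1cc(C)cc(S(=O)(=O)c2c(C(=O)NC(C)c3ccccc3F)[nH]c3ccc(Cl)cc23)c1` is not yet measured. It differs from compound 2 in one place: 2-fluorophenyl in place of ((pyridin-4-yl)methyl)carbamoyl on a saturated chain carbon bound to an amide-type nitrogen and a saturated chain carbon. Within the data shown here, the single measured step, from compound 1 to compound 2, exchanged one ring-bearing chain end for another of the same size and moved the numbers only within the scatter. Among the measured compounds shown here, no measured step removes a whole carbamoyl-linked group as the change to compound 3 does, so there is no direct guide. For the measured compounds named here, on the one step that exists, a shift beyond the scatter is not expected, and the number for compound 3 is estimated to change by a 1.3-fold higher number from compound 2 to compound 3 (0.11 log units; within the scatter).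

Compound 3 is therefore expected to give about 25000 nM in this assay, within a range of 8000 nM to 80000 nM.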

Compound 3, half-maximal cytotoxic concentration: > 51500 nM
Compound 3 ended at the assay's limit (the forecaster's own chance of this, stated with the estimate: 20%); at least 2.0-fold (0.31 log units) between middle value and limit.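

In this assay compound 3 gives > 51500 nM, which is a limit of the assay and not a number. Even so, 2-fluorophenyl in place of ((pyridin-4-yl)methyl)carbamoyl on this saturated chain carbon gives an at least 2.6-fold higher number from compound 2 to compound 3 (0.42 log units; beyond the scatter), the first step in the series to pass the scatter, so this place can move the read-out towards lower toxicity in this test, which the exchange of chain ends in the earlier pair did not show. The other comparison, 1-(2-fluorophenyl)ethyl in place of ((1-phenylethyl)carbamoyl)methyl on an amide-type nitrogen, gives an at least 1.7-fold higher number from compound 1 to compound 3 (0.24 log units; that floor lies within the scatter), so on its own it fixes no difference.

From the compounds shown here alone, how far the true value of compound 3 lies past the top of the measured range stays unknown: the limit of > 51500 nM in this assay, at which 1 of the 3 values shown sits. The change also swaps a whole group at once, so these compounds cannot separate the part played by the loss of the carbonyl and pyridine ring from that of the fluorine, and they say nothing about a simple phenyl, an amine or a carboxylic acid on that same carbon.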